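Triazolopyridine in Place of Imidazopyridine: Compound 3 Expected

The source may report more compounds than this note shows. Statements on the series, on what has been measured and on what is new or still open speak of the compounds shown alone.

Among the compounds with values here, compound 2 `Cc1cn2cc(C[C@H](C)CN3C[C@@H]4CCCC[C@@H]4[C@H](C(=O)N4CCN(c5ccc(F)c(F)c5)CC4)C3)ccc2n1` gives 107 nM in an assay on isolated protein for binding affinity to somatostatin receptor type 3 (Homo sapiens) (on this read-out lower numbers stand for tighter binding and higher numbers for weaker binding), the higher of the two numbers measured so far; compound 1 `C[C@@H](Cc1ccc2ocnc2c1)CN1C[C@@H]2CCCC[C@@H]2[C@H](C(=O)N2CCN(c3ccc(F)c(F)c3)CC2)C1` gives 11 nM, and the only measured step, a 9.7-fold higher number from compound 1 to compound 2 (0.99 log units; beyond the scatter), lies beyond the scatter. Compound 3 `C[C@@H](Cc1ccc2ncnn2c1)CN1C[C@@H]2CCCC[C@@H]2[C@H](C(=O)N2CCN(c3ccc(F)c(F)c3)CC2)C1` carries the change (a group of 9 heavy atoms (6 carbon, 3 nitrogen; one five-membered aromatic ring with 3 hetero atoms, one six-membered aromatic ring with 1 hetero atom) in place of a group of 10 heavy atoms (8 carbon, 2 nitrogen; one five-membered aromatic ring with 2 hetero atoms, one six-membered aromatic ring with 1 hetero atom), on a saturated chain carbon, three bonds along the chain from an amine nitrogen in a ring). Within the data shown here, no measured step has this same change, so the one step from compound 1 to compound 2 gives only a loose guide to how much swapping this ring system shifts binding. Compound 3 is expected to give 60 nM, between 15 nM and 250 nM, an estimated step of a 1.8-fold lower number from compound 2 to compound 3 (0.25 log units; within the scatter).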

Compound 3, dissociation constant: 34.7 nM
Compound 3: middle estimate off by 1.7-fold (0.24 log units), on the high side; the measured number falls inside the stated range.
By their numbers in this assay, from the lowest: compound 1; then compound 3; then compound 2.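

In this assay, the group with a five-membered aromatic ring with 3 hetero atoms recovers part of the earlier loss, giving a 3.1-fold lower number from compound 2 to compound 3 (0.49 log units; beyond the scatter), yet it does not match the group in compound 1, as shown by a 3.2-fold higher number from compound 1 to compound 3 (0.50 log units; beyond the scatter). Both of these groups have 9 heavy atoms, so at this position, group size alone does not set the number. On these data alone, whether a plain phenyl ring or an amine on the ring pair would give a lower number stays open. No measurement shown explains these differences.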